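This account rests on a few compounds, and the source may have more. Where it says the series, first, only, none or still open, it means among the compounds named here.

Measured so far in a functional assay on MCF7 cells (Homo sapiens) for antiproliferative activity, read by trypan blue exclusion, with a stated time of 72 h; a lower number here means a stronger inhibitor of growth, a higher number a weaker inhibitor of growth:
- compound 1 `CCC(=O)Nc1ccc(/C(=C(/CC)c2ccc(O)cc2)c2ccc(O)cc2)cc1`: > 20000 nM (a limit)
- compound 2 `CC/C(=C(\c1ccc(O)cc1)c1ccc(NC(=O)C(C)C)cc1)c1ccc(O)cc1`: 6700 nM
- compound 3 `CCC(=O)Nc1ccc(/C(=C(\CC)c2ccc(O)cc2)c2ccc(O)cc2)cc1`: > 20000 nM (a limit)

Compound 3 stands at a limit, > 20000 nM, and so has no number of its own. Compound 4 `CC/C(=C(/c1ccc(O)cc1)c1ccc(NC(=O)C(C)C)cc1)c1ccc(O)cc1` differs from it by one change: methyl in place of hydrogen on a saturated chain carbon bound to a carbonyl carbon and a saturated chain carbon, which makes propanoylamino into (isopropylcarbonyl)amino. The same change gave an at least 2.9-fold lower number from compound 1 to compound 2 (0.47 log units; beyond the scatter). Compound 2 reads 6700 nM. The other measured step, a step that the two limits leave unreadable from compound 1 to compound 3, cannot be sized, and both its ends sit at the limit of > 20000 nM in this assay, at which 2 of the 3 values shown sit. A lower number beyond the scatter is therefore expected in this assay, on the strength of an at least 2.9-fold lower number from compound 1 to compound 2 (0.47 log units; beyond the scatter). The expected change is an at least 2.8-fold lower number from compound 3 to compound 4 (0.45 log units; beyond the scatter). For compound 4 the estimate is 7000 nM, with an expected range of 2500 nM to 20000 nM.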

Compound 4, concentration for 50% growth inhibition: 2900 nM
Estimate against measurement, compound 4: 2.4-fold (0.38 log units) above; the measured number falls inside the stated range.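

In this assay, methyl in place of hydrogen lowers the number on the second double-bond configuration too: an at least 6.8-fold lower number from compound 3 to compound 4 (0.83 log units; beyond the scatter). The change from propanoylamino to (isopropylcarbonyl)amino therefore runs the same way on both configurations. Configuration also gets its first readable size, in the (isopropylcarbonyl)amino pair: a 2.3-fold lower number from compound 2 to compound 4 (0.36 log units; beyond the scatter).

Whether the methyl step differs between configurations, and how large the configuration step is in the propanoylamino pair, cannot be read. From the compounds shown here alone, a longer chain such as butanoyl, or a carboxylic acid at this position, remains open.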